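Nitro substitution on two cores, one measured step

This account rests on a few compounds, and the source may have more. Where it says the series, first, only, none or still open, it means among the compounds named here.

Measured so far in an assay on Myocardium (Cavia porcellus) for displacement of a labelled ligand from Voltage-dependent L-type calcium channel subunit alpha-1C (Homo sapiens); on this read-out higher numbers stand for weaker binding and lower numbers for tighter binding:
compound 1, `CSC1=NC(c2ccccc2SC)C2=C(O)OCC2=N1`: 45200 nM
compound 3, `CSC1=NC2/C(=C(/O)OCCCCCSc3ccccc32)C(C)=N1`: 18 nM
compound 2, `CSC1=NC(c2cc([N+](=O)[O-])ccc2SC)C2=C(O)OCC2=N1`: only a limit, > 50000 nM

Of the two numbers, compound 3 holds the lower one. How the core of compound 1 and the core of compound 3 differ is not broken down here.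

Among the measured compounds shown here, the one measured step is nitro in place of hydrogen on an aromatic carbon, giving an at least 1.1-fold higher number from compound 1 to compound 2 (0.04 log units; that floor lies within the scatter); compound 2 sits at the limit of > 50000 nM in this assay, at which 1 of the 3 values shown sits.

Compound 4, `CSC1=NC2/C(=C(/O)OCCCCCSc3ccc([N+](=O)[O-])cc32)C(C)=N1`, carries the same kind of change on compound 3: nitro in place of hydrogen on an aromatic carbon. The place is not the same: in compound 2 the nitro stands meta to a large group and para to a methylsulfanyl group, in compound 4 on a ring that is part of a fused or bridged system of three rings, meta to a fused ring and para to a fused ring.

For compound 4 the expected step is a 1.7-fold higher number from compound 3 to compound 4 (0.22 log units; within the scatter), resting on an at least 1.1-fold higher number from compound 1 to compound 2 (0.04 log units; that floor lies within the scatter), a step within the scatter. Compound 4 is estimated at 30 nM, expected between 8 nM and 120 nM.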

Compound 4, dissociation constant: 873 nM
Beside the measured number, compound 4's estimate is 29-fold (1.46 log units) below it, outside the stated range (above it).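

In this assay, nitro in place of hydrogen on an aromatic carbon of the core of compound 3 gives a 49-fold higher number from compound 3 to compound 4 (1.69 log units; beyond the scatter), a large loss of binding on that core. The value of compound 2, > 50000 nM, is a limit. The pairs therefore do not show whether the change carries the same size of step from one core to the other, and the nitro also stands at a different place in each pair: the same change on two cores in this assay, an at least 1.1-fold higher number (0.04 log units; that floor lies within the scatter) from compound 1 to compound 2 and a 49-fold higher number (1.69 log units; beyond the scatter) from compound 3 to compound 4; the limit leaves it open whether they differ

Still open, from the compounds shown here alone, is whether an amine or a carboxylic acid in the same place on the core of compound 3 would give a step of like size. Also open, going by these compounds, is how a nitro would behave elsewhere on that aromatic ring.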